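A few compounds are considered here, and "the series" means these few. Any claim that something is new, unique, unknown or untested is made for them only; others in the source may bear on it.

The series gathers three measured compounds and one unmeasured compound, all sharing one core. Compound 1 `COc1ccc(-c2nc(SC)n(C)c(=O)c2C#N)cc1` gives 73 ug/mL in a functional assay, with a stated time of 150 min; on this read-out higher numbers stand for weaker inhibition and lower numbers for stronger inhibition. Compound 3 `CSc1nc(-c2cccs2)c(C#N)c(=O)n1C` gives 87 ug/mL in this assay. Compound 2 `CCOC(=O)c1cnn(-c2nc(-c3ccccc3O)c(C#N)c(=O)n2C)c1N` gives 64 ug/mL in this assay, a number that lies within the usual scatter of compound 1 at 73 ug/mL and of compound 3 at 87 ug/mL, so no order among the three can be read from these numbers.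

Compound 4 `CCOC(=O)c1cnn(-c2nc(-c3ccccc3Cl)c(C#N)c(=O)n2C)c1N` differs from compound 2 in one place: chloro in place of hydroxy on an aromatic carbon. For the measured compounds named here, no measured pair shows this change, so there is no step to rest on, and the three numbers on hand spread over a range no wider than the scatter itself. The step from compound 2 to compound 4 is therefore expected to be small, a 1.1-fold higher number from compound 2 to compound 4 (0.04 log units; within the scatter), with no direction beyond the scatter claimed. Compound 4 is estimated at 70 ug/mL in this assay, within a range from 30 ug/mL to 160 ug/mL.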

Compound 4, half-maximal inhibitory concentration: 93 ug/mL
Compound 4: middle estimate off by 1.3-fold (0.12 log units), on the low side; measured number inside the range.
By their numbers in this assay, from the lowest: compounds 2, 1, 3 and 4 (each within the scatter of the next).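

For the compounds shown here, compound 4 and compound 2 form the first pair that differs in one place, and in this assay the pair gives a 1.5-fold higher number from compound 2 to compound 4 (0.16 log units; within the scatter) and so stays within the scatter. On an aromatic carbon ortho to a large group, then, the 2-hydroxyphenyl to 2-chlorophenyl exchange, which gives up the hydrogen-bond donor and acceptor counted for hydroxy, leaves no difference that this read-out can resolve. Nothing available here bears on the reason for this result.

From the compounds shown here alone, whether an amine, a methoxy group or a carboxylic acid at this place would give a step beyond the scatter remains open. The compounds shown also offer no second pair with this exchange, so whether it would read the same with other groups elsewhere on the shared core is unknown.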